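From compound 3 to compound 4: adding trifluoromethoxy

The compounds below may be only part of what the source reports. "The series", "measured", "known", "first", "only" and "open" are said of these compounds alone.

Measured in a functional assay on RAW264.7 cells (Mus musculus) for inhibition, read by Griess assay, with stated times of 1 h and 24 h; a higher number here means a weaker inhibitor, a lower number a stronger inhibitor:
- compound 1 `COCCOc1ccc(C(O)C2OC(=O)c3c(OC)cc(OC)cc32)cc1`: > 10000 nM
- compound 2 `COCCCCOc1ccc(C(O)C2OC(=O)c3c(OC)cc(OC)cc32)cc1`: 8210 nM
- compound 3 `COc1cc(OC)c2c(c1)C(C(O)c1ccc(OCc3ccccc3)cc1)OC2=O`: > 10000 nM

Compound 3 stands at > 10000 nM, which is a limit and not a number. This is the limit of > 10000 nM in this assay, at which 2 of the 3 values shown sit.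

Compound 4 `COc1cc(OC)c2c(c1)C(C(O)c1ccc(OCc3ccc(OC(F)(F)F)cc3)cc1)OC2=O` differs from it by one change: trifluoromethoxy in place of hydrogen on an aromatic carbon. This is trifluoromethoxy in place of hydrogen on an aromatic carbon, para to a large group.

For the measured compounds named here, no measured step changes that ring. The nearest steps alter the chain on the aromatic oxygen: an at least 1.2-fold lower number from compound 1 to compound 2 (0.08 log units; that floor lies within the scatter), an at least 1.2-fold higher number from compound 2 to compound 3 (0.08 log units; that floor lies within the scatter) and a step that the two limits leave unreadable from compound 1 to compound 3. On these steps, no change beyond the scatter is expected in this assay, in either direction.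

Compound 4 is estimated at 9000 nM, with an expected range from 3500 nM to 20000 nM. The expected step is an at least 1.1-fold lower number from compound 3 to compound 4 (0.04 log units; that floor lies within the scatter).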

Compound 4, half-maximal inhibitory concentration: 8140 nM
The estimate for compound 4 lay 1.1-fold (0.04 log units) above the measured number; the range from low to high includes it.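

In this assay, for the compounds shown here, this is the first measured change on the ring that carries the new group, and trifluoromethoxy there gives an at least 1.2-fold lower number from compound 3 to compound 4 (0.08 log units; that floor lies within the scatter). Against the other chains on the aromatic oxygen, 4-(trifluoromethoxy)phenyl gives a 1.0-fold lower number from compound 2 to compound 4 (0.00 log units; within the scatter) and an at least 1.2-fold lower number from compound 1 to compound 4 (0.08 log units; that floor lies within the scatter). Compound 1 and compound 3 each carry a limit, so their steps are floors and their true size stays unknown: the limit of > 10000 nM in this assay, at which 2 of the 4 values shown sit.

On these data alone, whether an amine or a carboxylic acid at this place would move the number beyond the scatter remains open. So does the effect of a chlorine atom elsewhere on that ring.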